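The source may report more compounds than this note shows. Statements on the series, on what has been measured and on what is new or still open speak of the compounds shown alone.

Compound 1 `CCN(CC)c1ccc(NC(=O)C2CCc3ccccc3C2)cc1` gives 2700 nM in an assay on isolated protein for binding affinity to growth hormone secretagogue receptor type 1 (Homo sapiens); on this read-out lower numbers stand for stronger inhibition and higher numbers for weaker inhibition. Compound 2 `CCN(CC)c1ccc(NC(=O)C2(NC(=O)OC(C)(C)C)CCc3ccccc3C2)cc1` gives 120 nM in this assay.

Within the data shown here, on the numbers in hand, compound 2 stands lowest of the two; its only neighbour is compound 1, separated by a 23-fold lower number from compound 1 to compound 2 (1.35 log units; beyond the scatter). Compound 3 `CCN(CC)c1ccc(NC(=O)C2(NC(=O)OCC(C)C)CCc3ccccc3C2)cc1` differs from compound 2 by isobutyl in place of tert-butyl on an oxygen next to a carbonyl group. Among the measured compounds shown here, the one measured step, a 23-fold lower number from compound 1 to compound 2 (1.35 log units; beyond the scatter), concerns adding the whole carbamate group rather than the shape of its alkyl part, so no measured step speaks directly to rearranging the same four carbons. Compound 3 is therefore expected to change little, a 1.3-fold higher number from compound 2 to compound 3 (0.12 log units; within the scatter), and is estimated at 160 nM, within 50 nM to 500 nM.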

Compound 3, half-maximal inhibitory concentration: 11 nM
Compound 3: middle estimate off by 15-fold (1.16 log units), on the high side; the whole stated range lies above it.
By their numbers in this assay, from the lowest: compound 3; then compound 2; then compound 1.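

In this assay, the arrangement of the alkyl part of the carbamate matters, not only its presence: with the same atoms joined differently, isobutyl in place of tert-butyl on the oxygen gives an 11-fold lower number from compound 2 to compound 3 (1.04 log units; beyond the scatter) and so reaches well beyond the scatter. Set against the hydrogen of the core, the whole (isobutoxycarbonyl)amino group gives a 250-fold lower number from compound 1 to compound 3 (2.39 log units; beyond the scatter) on the saturated ring carbon. No evidence at hand accounts for this difference.

As far as these compounds go, whether a longer chain or a benzyl group on that oxygen would lower the number further remains open, as does how an amine in place of the carbamate would compare.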